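Porcupine inhibitors: methoxyphenyl for fluorophenyl on a ring nitrogen

A few compounds are considered here, and "the series" means these few. Any claim that something is new, unique, unknown or untested is made for them only; others in the source may bear on it.

Measured compounds and values in an assay on L cells for inhibition of Protein-serine O-palmitoleoyltransferase porcupine (Mus musculus), read by reporter gene assay, with a stated time of 24 h; on this read-out lower numbers stand for an effect already at smaller amounts and higher numbers for an effect only at larger amounts of compound:
compound 1, `COc1ccccc1-n1nc(C(=O)NCC(=O)Nc2nc3ccccc3s2)c2ccccc2c1=O`, 10000 nM
compound 2, `O=C(CSc1nc2c(c(=O)n1-c1ccc(F)cc1)SCC2)Nc1nc2ccc(Cl)cc2s1`, 175 nM
compound 3, `O=C(CNC(=O)c1nn(-c2ccc(F)cc2)c(=O)c2ccccc12)Nc1nc2ccccc2s1`, > 25000 nM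

For compound 3 the read-out is a limit of the assay, > 25000 nM, not a number. Compound 1 shares the core of compound 3 and differs from it only by 2-methoxyphenyl in place of 4-fluorophenyl on an aromatic nitrogen; this gives an at least 2.5-fold lower number from compound 3 to compound 1 (0.39 log units; beyond the scatter), and the size of that step is bounded only from one side, since the value of compound 3 is one of the values at the limit of > 25000 nM in this assay, at which 1 of the 3 values shown sits. Compound 2 rests on a different core, and the difference between the two cores is not broken down here; in this assay compound 2 sits well below compound 1.

Compound 4, `COc1ccccc1-n1c(SCC(=O)Nc2nc3ccc(Cl)cc3s2)nc2c(c1=O)SCC2`, has not been measured. It differs from compound 2 by 2-methoxyphenyl in place of 4-fluorophenyl on an aromatic nitrogen, the same kind of change as that from compound 3 to compound 1, though the surroundings are not the same: in compound 4 the aromatic nitrogen is ortho to a large group and two atoms from the ring nitrogen, whereas in compound 1 it is next to the ring nitrogen and meta to a large group. Within the data shown here, because of the step of an at least 2.5-fold lower number from compound 3 to compound 1 (0.39 log units; beyond the scatter), the expected direction is a lower number than that of compound 2, but a smaller step is estimated, a 1.6-fold lower number from compound 2 to compound 4 (0.20 log units; within the scatter), since the one measured step is a lower bound on a different core. The estimated value for compound 4 in this assay is 110 nM, expected between 35 nM and 400 nM.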

Compound 4, half-maximal effective concentration: 50 nM
Compound 4: the middle estimate sits 2.2-fold (0.34 log units) above what was measured, and the stated range covers the measured number.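

In this assay, 2-methoxyphenyl in place of 4-fluorophenyl on an aromatic nitrogen gives a 3.5-fold lower number from compound 2 to compound 4 (0.54 log units; beyond the scatter), so the lower number seen on the core of compound 1 also appears on the core of compound 2. The change therefore carries over in direction between these two cores, but this does not establish a fixed size for the step, and two cores do not make a rule for the whole series: the same change on two cores in this assay, an at least 2.5-fold lower number (0.39 log units; beyond the scatter) from compound 3 to compound 1 and a 3.5-fold lower number (0.54 log units; beyond the scatter) from compound 2 to compound 4; the limit leaves it open whether they differ. The step on the core of compound 1 remains bounded from one side only, as compound 3 stands at a limit of the assay and not at a number: the limit of > 25000 nM in this assay, at which 1 of the 4 values shown sits.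

The compounds shown offer only these two aryl groups on that nitrogen, so they do not separate the gain from having methoxy from the loss of having fluorine; a plain phenyl on the same nitrogen of either core would bear on this. On these data alone, it also remains open whether a longer ether such as ethoxy, or an amine or a carboxylic acid in place of the methoxy group, would follow the same direction.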